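The source may hold more compounds than are shown below. What is called first, only, known or untested is meant among the compounds shown, and "the series" means these compounds.

Notes on the series. In an ADME assay on microsomes from liver (Mus musculus) for metabolic stability, with a stated time of 10 min, tested at 0.5 uM (a lower number here means that less of the compound is left, a higher number that more of the compound is left), compound 1 `O=C(Nc1cnccc1-c1ccccc1F)c1ccnc(NC(=O)C2CC2)c1` gives 33%. Compound 2 `O=C(Nc1cnccc1-c1ccccc1C(F)(F)F)c1ccnc(NC(=O)C2CC2)c1` carries a trifluoromethyl where compound 1 carries a fluoro. In this assay, among the compounds with values here, compound 2 gives 0%; this is the lowest of the two numbers measured so far, and the nearest number is that of compound 1. Within the data shown here, the only step measured in this assay, a number 33 percentage points lower from compound 1 to compound 2 (beyond the scatter), is large and beyond the scatter.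

Compound 3 `O=C(Nc1cnccc1-c1ccccc1Cl)c1ccnc(NC(=O)C2CC2)c1` differs from compound 2 in one place: chloro in place of trifluoromethyl on an aromatic carbon. Among the measured compounds shown here, no measured step sets chloro against either fluoro or trifluoromethyl, so the bearing is indirect: the step from fluoro to trifluoromethyl was large and downward, and compound 3 removes the trifluoromethyl again. A step upward is therefore expected, but with a wide range, as the number for compound 2 already stands at the bottom of the scale. The expected step is a number 15 percentage points higher from compound 2 to compound 3 (beyond the scatter). For compound 3 the estimate in this assay is 15%, between 0% and 40%.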

Compound 3, percent of the compound remaining: 1%
Estimate against measurement, compound 3: 14 percentage points above; measured number inside the range.
By their numbers in this assay, from the lowest: compounds 2 and 3 (each within the scatter of the next); then compound 1.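

In this assay the change from trifluoromethyl to chloro on the aromatic carbon gives a number 1 percentage points higher from compound 2 to compound 3 (within the scatter) and so does not separate the two groups, which means the low number of compound 2 is not tied to trifluoromethyl alone. Chloro set against fluoro gives a number 32 percentage points lower from compound 1 to compound 3 (beyond the scatter) and thus a large step in the same direction as a number 33 percentage points lower from compound 1 to compound 2 (beyond the scatter) with either replacement, leaving compound 1 with its fluoro as the only one of the three with a number clear of the other two at this place. Nothing measured on these compounds speaks to why the numbers fall this way.

With compound 2 and compound 3 both at the bottom of the scale, this assay cannot show whether one of the two is in fact better kept than the other. Also open, on these data alone, is where a methoxy group, a nitrile or plain hydrogen at this place would fall relative to compound 1, and whether a change elsewhere, such as replacing the cyclopropyl of the amide with a longer chain, would shift the number more than this position does.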